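Changing the group on the ring amine nitrogen

The source may report more compounds than this note shows. Statements on the series, on what has been measured and on what is new or still open speak of the compounds shown alone.

Compound 1, `Nc1scc(CN2CCN(c3cccc(Cl)c3Cl)CC2)c1C(=O)c1ccc(Cl)cc1`: -77%
Compound 2, `Nc1scc(CN2CCN(c3ccc(OC(F)(F)F)cc3)CC2)c1C(=O)c1ccc(Cl)cc1`: -74%
Compound 3, `Nc1scc(CN2CCN(C3CCCCCC3)CC2)c1C(=O)c1ccc(Cl)cc1`: -25%

All three were tested in a functional assay on CHO cells with adenosine receptor A1 (Homo sapiens) as the target, read by cAMP accumulation and immunoassay, with a stated time of 6 min, tested at 10 uM; a higher number here means a weaker effect of the compound at the concentration tested, a lower number a stronger effect. Compound 1 has the lowest number of the three, but compound 2 lies within the scatter of it: a number 3 percentage points higher from compound 1 to compound 2 (within the scatter). Compound 3 stands far apart, as the steps of a number 52 percentage points higher from compound 1 to compound 3 (beyond the scatter) and a number 49 percentage points higher from compound 2 to compound 3 (beyond the scatter) show. Both large steps come from putting cycloheptyl, a non-aromatic ring, on the amine nitrogen in place of an aromatic ring; the swap of one aromatic ring for another left the number essentially unchanged.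

Compound 4, `Nc1scc(CN2CCN(c3ccccc3F)CC2)c1C(=O)c1ccc(Cl)cc1`, has not yet been measured in this assay. It differs from compound 1 in one place: 2-fluorophenyl in place of 2,3-dichlorophenyl on an amine nitrogen in a ring. This change again keeps an aromatic ring on that nitrogen, so the step that bears on it most is the small one from compound 1 to compound 2, not the large ones to compound 3. The expected step is therefore a number 7 percentage points higher from compound 1 to compound 4 (within the scatter), within the scatter. Compound 4 is estimated at -70%, with a range from -85% to -50%.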

Compound 4, a percentage reported as activity, at one concentration (the size of the read-out at that concentration, not a potency): -15%
Beside the measured number, compound 4's estimate is 55 percentage points below it, outside the stated range (above it).
By their numbers in this assay, from the lowest: compounds 1 and 2 (each within the scatter of the next); then compounds 3 and 4 (each within the scatter of the next).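

Keeping an aromatic ring on the amine nitrogen is therefore not enough to hold the strong effect in this assay here: 2-fluorophenyl gives a number 62 percentage points higher from compound 1 to compound 4 (beyond the scatter) and also a number 59 percentage points higher from compound 2 to compound 4 (beyond the scatter) when it replaces the other aromatic group. With a number 10 percentage points higher from compound 3 to compound 4 (within the scatter) as the remaining step, aromatic compound 4 falls alongside non-aromatic compound 3, so compound 4 goes against any split of these compounds into aromatic and non-aromatic groups. Nothing available here explains why this single change on the ring has such a large effect.

From the compounds shown here alone, it remains open whether the effect depends on the chlorine atoms, the fluorine atom or the places they occupy on the ring. Plain phenyl, 2-chlorophenyl and 4-fluorophenyl on the same nitrogen would help separate these possibilities.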